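The compounds below may be only part of what the source reports. "The series", "measured", "known", "first", "only" and "open" are said of these compounds alone.

Working notes on the series, read in a functional assay on ECa-109 cells (Homo sapiens) for cytotoxicity, read by MTT assay, with a stated time of 72 h; a higher number here means a weaker inhibitor, a lower number a stronger inhibitor. Compound 2 `CN(C)c1ccc(C=C2C(=O)N(c3ccc(Cl)cc3)N(c3ccc(Cl)cc3)C2=O)cc1` gives > 128000 nM, which is a limit of the assay and not a number. Numbers exist for the two other measured compounds: compound 1 `O=C1C(=Cc2ccc(O)cc2)C(=O)N(c2ccc(Cl)cc2)N1c1ccc(Cl)cc1` gives 34200 nM, and compound 3 `O=C1C(=Cc2ccc(Br)cc2)C(=O)N(c2ccc(Cl)cc2)N1c1ccc(Cl)cc1` gives 12300 nM.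

Compound 4 `COc1cccc(C=C2C(=O)N(c3ccc(Cl)cc3)N(c3ccc(Cl)cc3)C2=O)c1` carries 3-methoxyphenyl in place of 4-(dimethylamino)phenyl on a double-bonded chain carbon bound to a double-bonded ring carbon. Within the data shown here, no measured step makes this exact change, and the 3-methoxyphenyl group has no measured value. The closest evidence comes from the steps that replace or introduce dimethylamino on an aromatic carbon: an at least 3.7-fold higher number from compound 1 to compound 2 (0.57 log units; beyond the scatter) and an at least 10-fold lower number from compound 2 to compound 3 (1.01 log units; beyond the scatter). Compound 2 thus sits on the high side of both measured neighbours, while the two neighbours themselves differ by a smaller margin: a 2.8-fold lower number from compound 1 to compound 3 (0.44 log units; beyond the scatter).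

Leaving the 4-(dimethylamino)phenyl group is therefore expected to lower the number, with the result landing near the values of compound 1 and compound 3. The expected change is an at least 4.2-fold lower number from compound 2 to compound 4 (0.63 log units; beyond the scatter). For compound 4 the estimated value is 30000 nM, with an expected range from 10000 nM to 100000 nM.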

Compound 4, half-maximal inhibitory concentration: 29000 nM
Beside the measured number, compound 4's estimate is 1.0-fold (0.01 log units) above it; measured number inside the range.
By their numbers in this assay, from the lowest: compound 3; then compounds 4 and 1 (each within the scatter of the next). At a limit, above all of these: compound 2.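

In this assay, the step away from 4-(dimethylamino)phenyl on this double-bonded chain carbon gives an at least 4.4-fold lower number from compound 2 to compound 4 (0.64 log units; beyond the scatter), so the high number of compound 2 does not carry over to 3-methoxyphenyl, although the counted hydrogen-bond donors and acceptors of the leaving and entering groups are the same. Against 4-hydroxyphenyl, the change gives a 1.2-fold lower number from compound 1 to compound 4 (0.07 log units; within the scatter), so these two groups cannot be told apart in this assay, whereas against 4-bromophenyl it gives a 2.4-fold higher number from compound 3 to compound 4 (0.37 log units; beyond the scatter), which leaves compound 3 with the lowest number of the four. Compound 2 stays at a limit of the assay and not a number: the limit of > 128000 nM in this assay, at which 1 of the 4 values shown sits.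

The step to 3-methoxyphenyl changes both the group and where it stands in the group's name, so without a 4-methoxyphenyl or 3-bromophenyl group the two changes cannot be separated. On these data alone, whether an aminophenyl or carboxyphenyl group at this position would fall below the number of compound 3 also stays open.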